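This account rests on a few compounds, and the source may have more. Where it says the series, first, only, none or still open, it means among the compounds named here.

Measured compounds in a functional assay on K562 cells (Homo sapiens) for cytotoxicity, read by MTT assay, with a stated time of 72 h; on this read-out lower numbers stand for stronger inhibition of growth and higher numbers for weaker inhibition of growth:
compound 1 `CS/C(=N\C(=O)c1csc([N+](=O)[O-])c1)NC(=O)c1csc([N+](=O)[O-])c1` gives 56900 nM
compound 2 `O=C(/N=C(/NC(=O)c1cc(-c2ccccc2)nc2ccccc12)[Se]Cc1ccccc1)c1cc(-c2ccccc2)nc2ccccc12` gives 9060 nM
compound 3 `CS/C(=N\C(=O)c1cc(-c2ccccc2)nc2ccccc12)NC(=O)c1cc(-c2ccccc2)nc2ccccc12` gives 34400 nM

Compound 1 and compound 3 carry different cores; the difference between the two cores is not broken down here, and the gap between their values is within the scatter. Compound 3 and compound 2 differ in one place, (a group of 8 heavy atoms (7 carbon, 1 selenium; one six-membered aromatic ring of carbon only) in place of a group of 2 heavy atoms (1 carbon, 1 sulfur; no ring), on a carbon with a double bond to nitrogen), and this change made a 3.8-fold lower number from compound 3 to compound 2 (0.58 log units; beyond the scatter). Compound 4 `O=C(/N=C(/NC(=O)c1csc([N+](=O)[O-])c1)[Se]Cc1ccccc1)c1csc([N+](=O)[O-])c1` has not yet been measured; it carries the same change on the core of compound 1, (a group of 8 heavy atoms (7 carbon, 1 selenium; one six-membered aromatic ring of carbon only) in place of a group of 2 heavy atoms (1 carbon, 1 sulfur; no ring), on a carbon with a double bond to nitrogen), at the same kind of place. Going by the values given here, only one measured example of this change exists, so the expectation rests on it alone. Among the compounds with values here, for compound 4 the step is expected to be a 3.8-fold lower number from compound 1 to compound 4 (0.58 log units; beyond the scatter), because a 3.8-fold lower number from compound 3 to compound 2 (0.58 log units; beyond the scatter) is the only guide available. Compound 4 is estimated at 15000 nM, with a likely range from 6000 nM to 40000 nM.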

Compound 4, concentration for 50% growth inhibition: 23500 nM
The estimate for compound 4 lay 1.6-fold (0.19 log units) below the measured number, within the range that was stated.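

In this assay, the group of 8 heavy atoms containing selenium and one six-membered aromatic ring, in place of methylsulfanyl, gives a 2.4-fold lower number from compound 1 to compound 4 (0.38 log units; beyond the scatter), the same direction as on the core of compound 3. The size of the step also carries over within what these data can resolve: the same change on two cores in this assay, a 3.8-fold lower number (0.58 log units; beyond the scatter) from compound 3 to compound 2 and a 2.4-fold lower number (0.38 log units; beyond the scatter) from compound 1 to compound 4, 1.6-fold (0.20 log units) apart, within the scatter of two such steps

This rests on two cores only and does not show that the change would carry to any other core. Nor does it separate the swap of sulfur for selenium from the addition of the ring, since both occur in one change.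

The compounds shown leave open how a benzylsulfanyl or a methylselanyl group would compare on either core. From the compounds shown here alone, an amine on the same carbon also remains open.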